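A Single Chloro on the Hydroxyethyl Side Chain

The compounds below may be only part of what the source reports. "The series", "measured", "known", "first", "only" and "open" are said of these compounds alone.

Compound 1 `Cc1cc(C(=O)O)ccc1CN1CCC[C@H](O[C@H](CO)c2ccccc2)[C@@H]1c1ccccc1` was tested in an assay on isolated protein for activation of cGMP-dependent protein kinase 1 (Homo sapiens), read by ADP-Glo, with stated times of 30 min and 2 h, in the presence of a further agent that is not named here (on this read-out higher numbers stand for an effect only at larger amounts of compound and lower numbers for an effect already at smaller amounts), and gives 25000 nM, the highest of the two numbers recorded here. Compound 2 `Cc1cc(C(=O)O)ccc1CN1CCC[C@H](O[C@H](CO)c2cc(Cl)cc(Cl)c2)[C@@H]1c1ccc(F)cc1` in this assay gives 18000 nM, a value that lies within the scatter of compound 1. Compound 3 `Cc1cc(C(=O)O)ccc1C(=O)N1CCC[C@H](O[C@H](CO)c2cc(Cl)cc(Cl)c2)[C@@H]1c1ccccc1` in this assay reaches only > 200000 nM, which is a limit of the assay rather than a number (the limit of > 200000 nM in this assay, at which 1 of the 3 values shown sits). Compound 4 `Cc1cc(C(=O)O)ccc1CN1CCC[C@H](O[C@H](CO)c2cccc(Cl)c2)[C@@H]1c1ccccc1` is not yet measured; it differs from compound 1 in one place: chloro in place of hydrogen on an aromatic carbon. Compound 2, which also carries chloro on that ring, sits with compound 1 within the scatter, so the step from compound 1 to compound 4 is expected to be small, a 1.3-fold lower number from compound 1 to compound 4 (0.10 log units; within the scatter), with no direction beyond the scatter. Compound 4 is therefore expected to give 20000 nM in this assay, between 8000 nM and 50000 nM.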

Compound 4, half-maximal effective concentration: 1300 nM
Compound 4: middle estimate off by 15-fold (1.19 log units), on the high side; the whole stated range lies above it.
By their numbers in this assay, from the lowest: compound 4; then compounds 2 and 1 (each within the scatter of the next). At a limit, above all of these: compound 3.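

Adding a single chloro to this aromatic carbon, meta to a large group, gives a 19-fold lower number from compound 1 to compound 4 (1.28 log units; beyond the scatter) in this assay, so this one position can strongly change the number. Compound 2 also carries chloro on this ring, but it differs from compound 1 in more than one place and so could not show the effect of this change alone. Nothing given here explains the step.

Going by these compounds, whether bromo, methyl or methoxy on this same carbon would give a similar step remains open. So does whether chloro would have a comparable effect on the other phenyl ring.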